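The source may report more compounds than this note shows. Statements on the series, on what has been measured and on what is new or still open speak of the compounds shown alone.

Measured compounds:
- Compound 1, `Cc1ccc(CN2CCC(CCNC(=O)/C=C/c3cc(C(C)(C)C)c(O)c(C(C)(C)C)c3)CC2)cc1`: 70100 nM
- Compound 2, `CC(C)(C)c1cc(/C=C/C(=O)NCCC2CCN(Cc3cccc(F)c3)CC2)cc(C(C)(C)C)c1O`: 58400 nM

Both were tested in an assay on isolated protein for inhibition of Amine oxidase [flavin-containing] A (Homo sapiens), read by fluorescence, with stated times of 15 min and 20 min; on this read-out lower numbers stand for stronger inhibition and higher numbers for weaker inhibition. Compound 1 gives 70100 nM, and compound 2 gives 58400 nM. Compound 2 carries the lowest of the two numbers, but the step of a 1.2-fold lower number from compound 1 to compound 2 (0.08 log units; within the scatter) is within the scatter, so the two compounds cannot be told apart on these measurements.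

Compound 3, `CC(C)(C)c1cc(/C=C/C(=O)NCCC2CCN(Cc3ccc(F)cc3)CC2)cc(C(C)(C)C)c1O`, has not yet been measured. It differs from compound 2 by 4-fluorophenyl in place of 3-fluorophenyl on a saturated chain carbon bound to an amine nitrogen in a ring. Within the data shown here, the only measured step that bears on this change is the one from compound 1 to compound 2, which also exchanged one group on the same saturated chain carbon and was a 1.2-fold lower number from compound 1 to compound 2 (0.08 log units; within the scatter). Among the measured compounds shown here, no measured pair compares two fluorophenyl groups with each other, so the effect of moving the fluorine within the ring is unknown here. Given that the one related step was within the scatter, no step beyond the scatter is expected in this assay, in either direction. The expected step of a 1.0-fold higher number from compound 2 to compound 3 (0.01 log units; within the scatter) is therefore estimated to stay within the scatter. Compound 3 is expected to give 60000 nM, with a range from 25000 nM to 150000 nM.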

Compound 3, half-maximal inhibitory concentration: 59600 nM
Estimate against measurement, compound 3: 1.0-fold (0.00 log units) above, and the stated range covers the measured number.
By their numbers in this assay, from the lowest: compounds 2, 3 and 1 (each within the scatter of the next).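

In this assay, among these compounds, the change from 3-fluorobenzyl to 4-fluorobenzyl gives a 1.0-fold higher number from compound 2 to compound 3 (0.01 log units; within the scatter), the first direct comparison of two fluorophenyl groups on a saturated chain carbon bound to an amine nitrogen in a ring, and on these numbers the two placements of the fluorine cannot be told apart. The second new comparison, fluoro in place of methyl on an aromatic carbon, gives a 1.2-fold lower number from compound 1 to compound 3 (0.07 log units; within the scatter), so exchanging these two small groups on the ring also produces no readable difference, and all three compounds remain indistinguishable in this assay. No other data are available to explain why these changes leave the number within the scatter.

As far as these compounds go, it remains open whether a different group at this position, such as a pyridine in place of the phenyl ring or a phenyl ring carrying a methoxy group or a carboxylic acid, would produce a step beyond the scatter. The compounds shown also leave open what a change elsewhere in the molecule, such as a longer chain on the amide nitrogen, would do.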